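Methoxy in place of tert-butyl on compound 2

The compounds below may be only part of what the source reports. "The series", "measured", "known", "first", "only" and "open" are said of these compounds alone.

Two compounds have numbers in a functional assay on BV-2 cells (Mus musculus) for inhibition, read by Griess assay, with stated times of 3 h and 24 h; on this read-out higher numbers stand for weaker inhibition and lower numbers for stronger inhibition:
Compound 1 `[O-][S+](/C=C/c1ccc(O)c(O)c1)Cc1ccc(Cl)cc1` gives 14000 nM.
Compound 2 `CC(C)(C)c1ccc(C[S+]([O-])/C=C/c2ccc(O)c(O)c2)cc1` gives 9300 nM.

Within the data shown here, compound 2 stands at the lower of the two numbers, with compound 1 as its only neighbour; the step of a 1.5-fold lower number from compound 1 to compound 2 (0.18 log units; within the scatter) is within the scatter, so the two cannot be ordered.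

Compound 3 `COc1ccc(C[S+]([O-])/C=C/c2ccc(O)c(O)c2)cc1` differs from compound 2 in one place: methoxy in place of tert-butyl on an aromatic carbon. Among the measured compounds shown here, the one measured step that bears on this change is the one from compound 1 to compound 2, where a tert-butyl took the place of a chloro on the same aromatic carbon, and that step a 1.5-fold lower number from compound 1 to compound 2 (0.18 log units; within the scatter) stayed within the scatter. Two different groups at this place have therefore given numbers that cannot be told apart, and nothing in the data points to the methoxy behaving otherwise. The expectation is accordingly a step of no size beyond the scatter, a 1.1-fold higher number from compound 2 to compound 3 (0.03 log units; within the scatter). Compound 3 is expected to give about 10000 nM in this assay, with a range from 4000 nM to 25000 nM.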

Compound 3, half-maximal inhibitory concentration: 33000 nM
Estimate against measurement, compound 3: 3.3-fold (0.52 log units) below; measured number outside the range, above it.
By their numbers in this assay, from the lowest: compounds 2 and 1 (each within the scatter of the next); then compound 3.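

In this assay the methoxy group gives weaker inhibition than either earlier group, with a 3.5-fold higher number from compound 2 to compound 3 (0.55 log units; beyond the scatter) when it replaces tert-butyl and a 2.4-fold higher number from compound 1 to compound 3 (0.37 log units; beyond the scatter) when it replaces chloro, though both steps are modest. This aromatic carbon, para to a large group, had looked indifferent while only chloro and tert-butyl had been compared, but it clearly does respond to what is placed on it. Compared with tert-butyl, the methoxy has fewer heavy atoms, includes an oxygen and adds a hydrogen-bond acceptor, but nothing available shows which of these differences, if any, accounts for the higher number.

The compounds shown leave open whether the rise goes with the oxygen or with the smaller group, a question that a methyl or an ethoxy group on the same carbon could help to separate. They also leave open how a hydroxyl, an amine or a carboxylic acid would read out at this place, and whether any group here could give stronger inhibition than chloro or tert-butyl.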